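The source may report more compounds than this note shows. Statements on the series, on what has been measured and on what is new or still open speak of the compounds shown alone.

The measured compounds:
compound 1, `Cc1nc2c3ccccc3ccc2c2nc3c(ccc4ccccc43)c(-c3ccccc3Cl)c12`: 74.6 ug/mL in a functional assay, read by spectrophotometry, with a stated time of 15 min; on this read-out higher numbers stand for weaker inhibition and lower numbers for stronger inhibition
compound 2, `Cc1nc2c3ccccc3ccc2c2nc3c(ccc4ccccc43)c(-c3ccccc3S)c12`: 49.6 ug/mL
compound 3, `Cc1ccc(-c2c3ccc4ccccc4c3nc3c2c(C)nc2c4ccccc4ccc32)cc1`: 68.7 ug/mL

All three share one core and differ only in the aryl group attached to it. The values sit close together: a 1.5-fold lower number from compound 1 to compound 2 (0.18 log units; within the scatter), a 1.1-fold lower number from compound 1 to compound 3 (0.04 log units; within the scatter) and a 1.4-fold higher number from compound 2 to compound 3 (0.14 log units; within the scatter). Compound 3 therefore stands second highest of the values shown, nearest to compound 1 and furthest from compound 2, but within the scatter of both.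

Compound 4, `Cc1nc2c3ccccc3ccc2c2nc3c(ccc4ccccc43)c(-c3cc([N+](=O)[O-])ccc3N)c12`, has not yet been measured. Its difference from compound 3 is 2-amino-5-nitrophenyl in place of 4-methylphenyl on an aromatic carbon.

For the measured compounds named here, no measured step introduces an amino or a nitro group, so none bears on this change directly. The steps that exist, exchanging chloro for sulfanyl or the whole 2-chlorophenyl or 2-sulfanylphenyl for 4-methylphenyl, all stayed within the scatter. On that record the aryl group has so far moved this assay little, and a step in either direction beyond the scatter is not expected for compound 4, while the new donor and acceptors leave room for a modest shift.

The estimate for compound 4 is 60 ug/mL, with a range from 30 ug/mL to 130 ug/mL, corresponding to an expected step of a 1.1-fold lower number from compound 3 to compound 4 (0.06 log units; within the scatter).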

Compound 4, half-maximal inhibitory concentration: 43.3 ug/mL
The estimate for compound 4 lay 1.4-fold (0.14 log units) above the measured number; measured number inside the range.
By their numbers in this assay, from the lowest: compounds 4, 2, 3 and 1 (each within the scatter of the next).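

At the aromatic carbon opposite the ring nitrogen, 2-amino-5-nitrophenyl brings 10 heavy atoms, 1 hydrogen-bond donor and 3 hydrogen-bond acceptors where 4-methylphenyl has 7 heavy atoms and neither donor nor acceptor, yet in this assay the exchange gives only a 1.6-fold lower number from compound 3 to compound 4 (0.20 log units; within the scatter). Set against the two ortho-substituted aryl groups, the same group gives a 1.1-fold lower number from compound 2 to compound 4 (0.06 log units; within the scatter) and a 1.7-fold lower number from compound 1 to compound 4 (0.24 log units; within the scatter), so the insensitivity seen among the earlier compounds now extends to a larger aryl group carrying amino and nitro, with no compound among the four going against it. Nothing beyond these assay numbers is available to account for this flat result.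

Going by these compounds, the amino and nitro groups appear only together, so what each contributes alone remains open, as does the result with unsubstituted phenyl at this position. On these data alone, it is also open whether the flat record would hold for a group without an aryl ring there, such as a carboxylic acid, a morpholine or a longer alkyl chain, or for any change to the methyl group on the shared core.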